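Isopropylsulfanyl for Cyclopropylamino: Cytotoxicity Expected Unchanged

The compounds below may be only part of what the source reports. "The series", "measured", "known", "first", "only" and "open" are said of these compounds alone.

compound 1, `CCCCCCCCOc1nc(N)nc2c1ncn2/C=C1/CC1(CO)CO`: > 20000 nM
compound 2, `Nc1nc(NC2CC2)c2ncn(/C=C3/CC3(CO)CO)c2n1`: > 20000 nM

In an ADME assay on CCRF-HSB-2 cells (Homo sapiens) for cytotoxicity, with a stated time of 7 days (a lower number here means that less compound is tolerated, a higher number that more compound is tolerated), compound 1 reaches only a limit, not a number. Compound 2 likewise stands at a limit, (the limit of > 20000 nM in this assay, at which 2 of the 2 values shown sit). The step that the two limits leave unreadable from compound 1 to compound 2 therefore cannot be sized. Compound 3, `CC(C)Sc1nc(N)nc2c1ncn2/C=C1/CC1(CO)CO`, differs from compound 2 by isopropylsulfanyl in place of cyclopropylamino on an aromatic carbon. Within the data shown here, no measured step speaks to this change, since the single step recorded is unreadable. For compound 3 the expected step is a step that the limit leaves unreadable from compound 2 to compound 3, nothing beyond the scatter. Compound 3 is thus estimated at 30000 nM, within 15000 nM to 100000 nM, most likely again reported only as a limit.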

Compound 3, half-maximal cytotoxic concentration: 94000 nM
Beside the measured number, compound 3's estimate is 3.1-fold (0.50 log units) below it; measured number inside the range.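

Compound 3 gives a number, but its steps from compound 1 and from compound 2 cannot be read, because both of those compounds stand at a limit: the limit of > 20000 nM in this assay, at which 2 of the 3 values shown sit.

The compounds shown leave open how large any difference among octyloxy, cyclopropylamino and isopropylsulfanyl on this aromatic carbon is.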